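Swapping a Side Group on the Five-Membered Ring

A few compounds are considered here, and "the series" means these few. Any claim that something is new, unique, unknown or untested is made for them only; others in the source may bear on it.

Compound 1 `CCc1cccc2c(OC)c(-c3occ(C)c3C(=S)OC)ccc12` was tested in a functional assay on KBVIN cells (Homo sapiens) for cytotoxicity, read by MTT assay, with a stated time of 72 h (on this read-out higher numbers stand for an effect only at larger amounts of compound and lower numbers for an effect already at smaller amounts), where compound 1 gives 5.1 ug/mL. That is the highest of the two numbers in hand. Compound 2 `CCOc1c(-c2occ(C)c2C(=O)OC)ccc2c(CC)cccc12` gives 1.7 ug/mL in this assay, a lower number beyond the usual scatter, but compound 2 differs from compound 1 in more than one place. Compound 3 `CCc1cccc2c(OC)c(-c3occ(C)c3COC)ccc12` carries a group of 3 heavy atoms (2 carbon, 1 oxygen; no ring) in place of a group of 4 heavy atoms (2 carbon, 1 oxygen, 1 sulfur; no ring), on an aromatic carbon. Among the compounds with values here, no single-point step between measured compounds is available to calibrate this change. Compound 3 is expected to give a somewhat higher number, a step of a 1.6-fold higher number from compound 1 to compound 3 (0.20 log units; within the scatter) near the edge of the scatter, with an estimate of 8 ug/mL and a range from 2.5 ug/mL to 25 ug/mL.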

Compound 3, concentration for half-maximal effect: 8.8 ug/mL
Compound 3: middle estimate off by 1.1-fold (0.04 log units), on the low side; measured number inside the range.
By their numbers in this assay, from the lowest: compound 2; then compounds 1 and 3 (each within the scatter of the next).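

At this aromatic carbon of the five-membered ring, methoxymethyl in place of the larger group of compound 1 gives a 1.7-fold higher number from compound 1 to compound 3 (0.24 log units; within the scatter) in this assay on the shared core. A group without sulfur and without a double bond outside the aromatic rings therefore still gives a number within the scatter of compound 1. Nothing at hand bears on the reason for this result.

Going by these compounds, whether a carboxylic acid or an amine at this position would stay within that scatter remains open. So does the outcome for a chain longer than methoxymethyl.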